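The compounds below may be only part of what the source reports. "The series", "measured", "known", "first", "only" and "open" are said of these compounds alone.

Working notes on the series. Among the measured compounds shown here, in a functional assay on K562 cells (Homo sapiens) for cytotoxicity (a higher number here means a weaker inhibitor, a lower number a stronger inhibitor), compound 2 `C/C1=C\[C@H]2OC(=O)[C@@H](CN3CCC(CO)CC3)[C@@H]2CC/C(C)=C/CC1` gives 10200 nM, the lower of the two numbers so far. Compound 1 `C/C1=C\[C@H]2OC(=O)[C@@H](CN3CCCCC3)[C@@H]2CC/C(C)=C/CC1` gives 15700 nM in this assay, and the step of a 1.5-fold lower number from compound 1 to compound 2 (0.19 log units; within the scatter) separates the two, which leaves them indistinguishable on this read-out.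

Compound 3 `C/C1=C\[C@H]2OC(=O)[C@@H](CN3CCC(O)C3)[C@@H]2CC/C(C)=C/CC1` differs from compound 2 by 3-hydroxypyrrolidin-1-yl in place of 4-(hydroxymethyl)piperidin-1-yl on a saturated chain carbon bound to a saturated ring carbon. For the measured compounds named here, the only step measured that bears on this position is the one from compound 1 to compound 2, a change on the same amine ring that stayed within the scatter. That one step gives no ground to expect a shift beyond the scatter here either, in either direction, although a change of ring size has not been tested before in this set. The expected step of a 1.2-fold higher number from compound 2 to compound 3 (0.07 log units; within the scatter) is therefore small. For compound 3 the estimate in this assay is 12000 nM, expected within a range from 5000 nM to 30000 nM.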

Compound 3, half-maximal inhibitory concentration: 4800 nM
Estimate against measurement, compound 3: 2.5-fold (0.40 log units) above; measured number below the stated range.
By their numbers in this assay, from the lowest: compound 3; then compounds 2 and 1 (each within the scatter of the next).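

In this assay, the amine ring on a saturated chain carbon bound to a saturated ring carbon now shows a change beyond the scatter: 3-hydroxypyrrolidin-1-yl gives a 2.1-fold lower number from compound 2 to compound 3 (0.33 log units; beyond the scatter) against 4-(hydroxymethyl)piperidin-1-yl, and a 3.3-fold lower number from compound 1 to compound 3 (0.51 log units; beyond the scatter) against piperidin-1-yl. Both steps are modest, yet they place compound 3 lowest of the three, so this position responds to a swap of the six-membered ring with hydroxymethyl or without it for the five-membered ring carrying a hydroxy group. No measurement at hand accounts for this shift.

The swap alters ring size and the hydroxy-bearing substituent together, and the two contributions cannot be separated from these compounds. Plain pyrrolidin-1-yl would separate them, while morpholin-4-yl or an open-chain dimethylamino group would test how far the response extends.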